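The source may hold more compounds than are shown below. What is called first, only, known or untested is meant among the compounds shown, and "the series" means these compounds.

Measured in a functional assay on MDA-MB-231 cells (Homo sapiens) for antiproliferative activity, read by WST assay, with a stated time of 72 h; on this read-out lower numbers stand for stronger inhibition of growth and higher numbers for weaker inhibition of growth:
Compound 1 `N=C(N)c1ccc(/N=N/Nc2cccc(C#Cc3ccccn3)c2)cc1` gives 14400 nM
Compound 2 `N=C(N)c1ccc(/N=N/Nc2ccccc2C#Cc2ccccc2)cc1` gives 5100 nM

Of these two compounds, compound 2 has the lower number and so the stronger inhibition of growth. Its gap to compound 1 lies beyond the usual scatter of repeated measurements. Compound 3 `C#Cc1ccccc1N/N=N/c1ccc(C(=N)N)cc1` has not yet been measured. It differs from compound 2 by hydrogen in place of phenyl on a triple-bonded carbon, so 2-phenylethynyl becomes ethynyl. For the measured compounds named here, no measured pair shows this change, which makes any forecast uncertain. Starting from compound 2 at 5100 nM, a moderate rise in this assay is expected, meaning weaker inhibition of growth. The expected change is a 2.2-fold higher number from compound 2 to compound 3 (0.33 log units; beyond the scatter), slightly beyond the scatter. For compound 3 the estimated value is 11000 nM, with an expected range of 3500 nM to 35000 nM.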

Compound 3, concentration for 50% growth inhibition: 23200 nM
Estimate against measurement, compound 3: 2.1-fold (0.32 log units) below; the measured number falls inside the stated range.
By their numbers in this assay, from the lowest: compound 2; then compounds 1 and 3 (each within the scatter of the next).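

In this assay, cutting 2-phenylethynyl back to ethynyl gives a 4.5-fold higher number from compound 2 to compound 3 (0.66 log units; beyond the scatter) and so weakens the inhibition of growth. This first direct comparison shows that, in this pair, the phenyl on the triple-bonded carbon contributes to activity, and that the triple bond capped with only a hydrogen does not retain the level of compound 2. No measurement at hand explains this loss.

As far as these compounds go, it remains open whether an aromatic ring is needed at this place, or whether a methyl, a cyclohexyl or a longer alkyl chain on the same triple-bonded carbon would serve as well. The compounds shown also leave open how an amine or a carboxylic acid on the phenyl of compound 2 would change growth inhibition.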